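A few compounds are considered here, and "the series" means these few. Any claim that something is new, unique, unknown or untested is made for them only; others in the source may bear on it.

Of the compounds shown here, two on the shared core have numbers so far in a functional assay on A549 cells (Homo sapiens) for antiproliferative activity, read by MTT assay, with a stated time of 72 h; a higher number here means a weaker inhibitor, a lower number a stronger inhibitor. Compound 1 `CCOc1ccc(-c2ccc3ncn(-c4cc(OC)c(OC)c(OC)c4)c3c2)cc1`, with an ethoxy group on its outer phenyl ring, gives 8550 nM. Compound 2 `COc1cc(-n2cnc3ccc(-c4ccc(C(C)=O)cc4)cc32)cc(OC)c1OC`, with an acetyl group in that place, gives 2510 nM, the lower of the two numbers in this assay.

The next compound is compound 3 `COc1ccc(-c2ccc3ncn(-c4cc(OC)c(OC)c(OC)c4)c3c2)cc1F`, and the change is 3-fluoro-4-methoxyphenyl in place of 4-acetylphenyl on an aromatic carbon. In words, it is 3-fluoro-4-methoxyphenyl in place of 4-acetylphenyl on an aromatic carbon.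

Within the data shown here, only one measured step bears on this change: a 3.4-fold lower number from compound 1 to compound 2 (0.53 log units; beyond the scatter). Compound 3 gives up the acetyl group and carries a methoxy group instead of an ethoxy group, so that step, read backwards, is the nearest guide. Among the measured compounds shown here, no measured compound carries the fluoro group, so its contribution is unknown. A modest move towards a higher number in this assay is therefore expected, no larger than about the size of that step, and possibly within the scatter.

The expected step is a 1.8-fold higher number from compound 2 to compound 3 (0.25 log units; within the scatter). The estimate for compound 3 is 4500 nM, with an expected range from 1500 nM to 13000 nM.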

Compound 3, half-maximal inhibitory concentration: 1430 nM
Compound 3: the middle estimate sits 3.1-fold (0.50 log units) above what was measured; the measured number lies below the stated range.
By their numbers in this assay, from the lowest: compounds 3 and 2 (each within the scatter of the next); then compound 1.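

In this assay, 3-fluoro-4-methoxyphenyl in place of 4-acetylphenyl gives a 1.8-fold lower number from compound 2 to compound 3 (0.24 log units; within the scatter) at this position, so compound 3 and compound 2 cannot be told apart here despite their different substituents. The acetyl group is therefore not required for a number at this level, and the carbonyl seen in compound 2 is not the only route away from the number of compound 1. Replacing 4-ethoxyphenyl with 3-fluoro-4-methoxyphenyl gives a 6.0-fold lower number from compound 1 to compound 3 (0.78 log units; beyond the scatter) and is the largest step among the three compounds, although no measurement available here offers an explanation for it.

On these data alone, the replacement from compound 1 to compound 3 changes the fluoro group and the alkoxy group together, so the share of each in that step stays open. Also open, as far as these compounds go, is how this assay would respond at this position to an amine, a carboxylic acid or a longer alkoxy chain on the outer phenyl ring, and whether any of these would move the number beyond the scatter from compound 3.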